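A few compounds are considered here, and "the series" means these few. Any claim that something is new, unique, unknown or untested is made for them only; others in the source may bear on it.

Compounds measured so far, all in a functional assay on HCT-116 cells (Homo sapiens) for inhibition, read by MTT assay, with a stated time of 48 h; a lower number here means a stronger inhibitor, a higher number a weaker inhibitor:
compound 1 `Clc1ccccc1CSc1nnc(-c2ccncc2)n1-c1ccccc1` gives 13900 nM;
compound 2 `Fc1cccc(F)c1CSc1nnc(-c2ccncc2)n1-c1ccccc1` gives 22100 nM;
compound 3 `O=C(CSc1nnc(-c2ccncc2)n1-c1ccccc1)N/N=C/c1ccccc1` gives 14700 nM.

Compound 3 stands second highest of the three numbers, with compound 1 nearest and compound 2 furthest, both within the scatter of it. Compound 4 `O=C(CSc1nnc(-c2ccncc2)n1-c1ccccc1)N/N=C/c1cc(Br)cc(Br)c1O` differs from compound 3 by 3,5-dibromo-2-hydroxyphenyl in place of phenyl on a carbon with a double bond to nitrogen. For the measured compounds named here, the only measured step, a 1.6-fold higher number from compound 1 to compound 2 (0.20 log units; within the scatter), concerns a different part of the shared core and stayed within the scatter, so no step here bears directly on the change to compound 4. In this assay compound 4 is therefore expected to move no further than the scatter, a step of a 1.5-fold lower number from compound 3 to compound 4 (0.17 log units; within the scatter). Compound 4 is estimated at 10000 nM, within 3000 nM to 30000 nM.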

Compound 4, half-maximal inhibitory concentration: 4500 nM
Estimate against measurement, compound 4: 2.2-fold (0.35 log units) above, within the range that was stated.
By their numbers in this assay, from the lowest: compound 4; then compounds 1, 3 and 2 (each within the scatter of the next).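

In this assay, 3,5-dibromo-2-hydroxyphenyl in place of phenyl on the carbon with a double bond to nitrogen gives a 3.3-fold lower number from compound 3 to compound 4 (0.51 log units; beyond the scatter), a modest step. It is the first step among these compounds to pass beyond the scatter, so this position answers to a change of group in a way the earlier change on the chain carbon bound to sulfur did not show. Nothing at hand explains the shift.

Going by these compounds, because the hydroxyl and both bromine atoms enter together, their separate shares remain open. So does the outcome with a methoxy group or chlorine atoms on that ring.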